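The source may report more compounds than this note shows. Statements on the series, on what has been measured and on what is new or still open speak of the compounds shown alone.

Compound 1 `O=C(COc1cccc2ccccc12)N/N=C/c1ccc(O)cc1` is the compound with the higher of the two numbers in an ADME assay on HEL cells (Homo sapiens) for cytotoxicity (a lower number here means that less compound is tolerated, a higher number that more compound is tolerated), where compound 1 gives 60.6 ug/mL. Compound 2 `COc1cc(/C=N/NC(=O)COc2cccc3ccccc23)cc(OC)c1OC` gives 47.9 ug/mL in this assay, a difference from compound 1 that lies within the scatter. Compound 3 `O=C(COc1cccc2ccccc12)N/N=C/c1ccccc1` differs from compound 1 by hydrogen in place of hydroxy on an aromatic carbon. Among the measured compounds shown here, no measured pair shows this change, so its effect in this assay is unknown. A small step, not beyond the scatter and in either direction, is expected from compound 1 to compound 3, that is a 1.2-fold lower number from compound 1 to compound 3 (0.08 log units; within the scatter). Compound 3 is therefore estimated at 50 ug/mL, within a range of 25 ug/mL to 100 ug/mL.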

Compound 3, half-maximal cytotoxic concentration: 64.5 ug/mL
The estimate for compound 3 lay 1.3-fold (0.11 log units) below the measured number, and the stated range covers the measured number.
By their numbers in this assay, from the lowest: compounds 2, 1 and 3 (each within the scatter of the next).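

In this assay, among the compounds shown here, hydrogen in place of hydroxy on this aromatic carbon gives a 1.1-fold higher number from compound 1 to compound 3 (0.03 log units; within the scatter), the first direct reading of this change. At this place, then, the numbers do not separate 4-hydroxyphenyl from phenyl on the shared core. No measurement here offers an explanation for this result. On these data alone, whether an amine, a carboxylic acid or a longer chain at the same place would also leave the number within the scatter remains open. A single pair also cannot show whether the change behaves the same way on another core.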